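This account rests on a few compounds, and the source may have more. Where it says the series, first, only, none or still open, it means among the compounds named here.

Compound 1 `O=C(Nc1cccc(-n2cc(-c3ccncc3)c(-c3ccc(Cl)c(O)c3)n2)c1)Nc1cccc(C(F)(F)F)c1` in a functional assay on CCRF-CEM cells (Homo sapiens) for inhibition, read by sulforhodamine B assay, with a stated time of 48 h (a lower number here means a stronger inhibitor of growth, a higher number a weaker inhibitor of growth), reaches only a limit of the assay, > 32500 nM.
Compound 2 `COc1cc(-c2nn(-c3cccc(NC(=O)c4ccc(Cl)c(C(F)(F)F)c4)c3)cc2-c2ccncc2)ccc1Cl` in this assay likewise reaches only a limit, > 32500 nM.
Compound 3 `O=C(Nc1cccc(-n2cc(-c3ccncc3)c(-c3ccc(Cl)c(O)c3)n2)c1)Nc1cc(C(F)(F)F)cc(C(F)(F)F)c1` in this assay gives 6780 nM.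

Compound 2 therefore stands at the weak end of what has been measured, and its value is a limit rather than a number; it shares that position with one other compound, as the limit of > 32500 nM in this assay, at which 2 of the 3 values shown sit, records. Compound 4 `COc1cc(-c2nn(-c3cccc(NC(=O)c4ccccc4)c3)cc2-c2ccncc2)ccc1Cl` differs from compound 2 in one place: phenyl in place of 4-chloro-3-(trifluoromethyl)phenyl on a carbonyl carbon. Going by the values given here, no measured step involves the same change. Among the compounds with values here, the only measured step, an at least 4.7-fold lower number from compound 1 to compound 3 (0.68 log units; beyond the scatter), concerns a different group in a different part of the molecule, and it shows that adding a trifluoromethyl there gave a lower number. Removing a trifluoromethyl together with a chlorine, as in compound 4, is not the same change, and compound 2 already sits at a limit, so the most that can be expected is that compound 4 stays at or beyond that limit. Compound 4 is estimated at 45000 nM, within 20000 nM to 120000 nM. The expected step is a step that the limit leaves unreadable from compound 2 to compound 4, most likely again reported only as a limit.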

Compound 4, concentration for total growth inhibition: > 100000 nM
Compound 4 gave a limit, no number; the forecaster's own chance of this, stated with the estimate: 85%; middle value at least 2.2-fold (0.34 log units) away from the limit.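

Compound 2 reaches only a limit, > 32500 nM. Going by these compounds alone, compound 4 likewise reaches only a limit, > 100000 nM, and no step from compound 2 to compound 4 can be read. From the compounds shown here alone, what stays open is whether phenyl and 4-chloro-3-(trifluoromethyl)phenyl on a carbonyl carbon differ at all in this assay.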